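This account rests on a few compounds, and the source may have more. Where it says the series, first, only, none or still open, it means among the compounds named here.

Measured compounds:
compound 1, `COc1cc(/C=C/C(=O)/C=C(/C=C/c2ccc(OC(C)=O)c(OC)c2)NC2CCCCC2)ccc1OC(C)=O`: 0.01%
compound 2, `C=CCNC(=C\C(=O)/C=C/c1ccc(O)c(OC)c1)/C=C/c1ccc(O)c(OC)c1`: 0.1%
compound 3, `COc1cc(/C=C/C(=O)/C=C(/C=C/c2ccc(O)c(OC)c2)NC2CCCCC2)ccc1O`: 0.13%

In a functional assay for inhibition, read by spectrophotometry, with a stated time of 30 min, tested at 1 uM (on this read-out lower numbers stand for less inhibition and higher numbers for more inhibition at the one concentration tested (going by the name of the read-out)), compound 1 gives 0.01%. Compound 2 gives 0.1% and compound 3 gives 0.13%; both differ from the figure of compound 1 by amounts inside the usual scatter, so the three measured compounds sit together at essentially no inhibition, and none can be set apart from the others.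

Compound 4, `CCC(C)NC(=C\C(=O)/C=C/c1ccc(OC(C)=O)c(OC)c1)/C=C/c1ccc(OC(C)=O)c(OC)c1`, has not been measured. It differs from compound 1 in one place: sec-butyl in place of cyclohexyl on an amine nitrogen

Going by the values given here, the only measured step that bears on a change at the amine nitrogen is the one from compound 2 to compound 3, a number 0 percentage points higher from compound 2 to compound 3 (within the scatter). That exchange of one nitrogen substituent for another left this assay unchanged within the scatter, and compound 3 also carries free phenols where compound 1 and compound 4 carry acetates, so the comparison is not exact. Among the compounds with values here, still, with all three measured values at the floor of the read-out and the one relevant step flat, no movement beyond the scatter is expected from the exchange of cyclohexyl for sec-butyl.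

Compound 4 is therefore expected to give 0.1%, with a range of 0% to 4%, the estimate meaning a step of a number 0.1 percentage points higher from compound 1 to compound 4 (within the scatter).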

Compound 4, a percentage reported as inhibition, at one concentration (the size of the read-out at that concentration, not a potency): 0%
Beside the measured number, compound 4's estimate is 0.1 percentage points above it; measured number inside the range.
By their numbers in this assay, from the lowest: compounds 4, 1, 2 and 3 (each within the scatter of the next).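

Read in this assay, sec-butyl in place of cyclohexyl on the amine nitrogen gives a number 0 percentage points lower from compound 1 to compound 4 (within the scatter), so replacing the six-membered carbon ring with an open chain produces no readable change in this acetate-bearing pair. The earlier flat step at this nitrogen, a number 0 percentage points higher from compound 2 to compound 3 (within the scatter), came from a pair with free phenols, so the same position is now also flat with acetates in place, although all of these values sit at essentially no inhibition and show only that none of the three nitrogen substituents (allyl, cyclohexyl, sec-butyl) brings inhibition at the one concentration tested, not that the position is unimportant. No measurement of any other property bears on this result.

Still open, as far as these compounds go, is whether a substituent of another kind on this nitrogen, such as a chain ending in a carboxylic acid or a basic amine, or a longer alkyl chain, would lift the read-out beyond the scatter. Also open, from the compounds shown here alone, is whether any compound in this set shows inhibition at a higher concentration, where differences between the nitrogen substituents could become readable.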